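Swapping the para substituent on the benzylthio arm

The source may report more compounds than this note shows. Statements on the series, on what has been measured and on what is new or still open speak of the compounds shown alone.

Two compounds in this series carry the propargylamine-bearing core with a benzylthio arm. Compound 1 `C#CCNC1CCc2c(SCc3cccc(C)c3)cccc21` carries a 3-methylphenyl there, and compound 2 `C#CCNC1CCc2c(SCc3ccc(Br)cc3)cccc21` a 4-bromophenyl. In an ADME assay on isolated protein for inhibition of Amine oxidase [flavin-containing] B (Homo sapiens) (on this read-out higher numbers stand for weaker inhibition and lower numbers for stronger inhibition), compound 1 gives only a limit, > 100000 nM, not a number. In this assay, among the compounds with values here, compound 2 gives 488 nM, the only numerical value in the set, so compound 2 stands alone as the sole measured point. The value of compound 1 is a limit (the limit of > 100000 nM in this assay, at which 1 of the 2 values shown sits). The step of an at least 200-fold lower number from compound 1 to compound 2 (2.31 log units; beyond the scatter) is large, but it changes both the position and the identity of the substituent at once, so it bears only loosely on the next change.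

Compound 3 `C#CCNC1CCc2c(SCc3ccc(OC)cc3)cccc21` differs from compound 2 by methoxy in place of bromo on an aromatic carbon, keeping the substituent at the position para to a large group. Within the data shown here, no measured step isolates a change of substituent at this position, so the direction is uncertain. A moderate rise in the number toward weaker inhibition is expected, a 6.1-fold higher number from compound 2 to compound 3 (0.79 log units; beyond the scatter). Compound 3 is therefore estimated at 3000 nM, within 700 nM to 20000 nM.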

Compound 3, half-maximal inhibitory concentration: 3960 nM
The estimate for compound 3 lay 1.3-fold (0.12 log units) below the measured number; low and high end bracket the measured number.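

In this assay, within the data shown here, methoxy in place of bromo gives an 8.1-fold higher number from compound 2 to compound 3 (0.91 log units; beyond the scatter), the first step here that changes the group alone while the place, para to a large group, stays the same. Unlike the step into compound 2, which starts from a limit, this one joins two numbers, so its size can be read directly, and it is modest but beyond the scatter. The change swaps a single bromine for two heavy atoms and brings in one hydrogen-bond acceptor, but these differences cannot be told apart here, and nothing given accounts for the step.

On these data alone, it remains open whether the number would keep moving with other groups at this place, as a chloro, an amine or a carboxylic acid there could show. Also open, as far as these compounds go, is whether the large step from compound 1 comes from the position of the substituent or from its identity, which a methyl at the place held by the bromo in compound 2 would separate.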